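Cyclohexyl to Isopentyl on the Ring Amide of Compound 2

This account rests on a few compounds, and the source may have more. Where it says the series, first, only, none or still open, it means among the compounds named here.

Within the data shown here, compound 2 `CC(C)(C)c1ccc(NC(=O)N2CCCN(C(=O)C3CCCCC3)CC2)cc1` stands alongside the only other measured compound in an in vitro ADME assay on microsomes from liver (Homo sapiens) for metabolic stability, read by LC-MS; on this read-out lower numbers stand for a shorter-lived compound and higher numbers for a longer-lived compound: compound 2 gives 0.0667 h, while compound 1 `CC(C)(C)c1ccc(NC(=O)N2CCCN(C(=O)CCC3CCCC3)CC2)cc1` gives 0.05 h, and the step of a 1.3-fold higher number from compound 1 to compound 2 (0.13 log units; within the scatter) lies within the scatter, so the two are read as level. Compound 3 `CC(C)CCC(=O)N1CCCN(C(=O)Nc2ccc(C(C)(C)C)cc2)CC1` differs from compound 2 in a single place: isopentyl in place of cyclohexyl on a carbonyl carbon. Among the measured compounds shown here, the only measured step that bears on this change, a 1.3-fold higher number from compound 1 to compound 2 (0.13 log units; within the scatter), likewise exchanged one saturated hydrocarbon group for another on that carbonyl carbon and stayed within the scatter. Nothing measured suggests a shift in either direction, so compound 3 is expected to move in this assay by no more than the scatter, an estimated step of a 1.1-fold lower number from compound 2 to compound 3 (0.05 log units; within the scatter). Compound 3 is therefore estimated at 0.06 h, with a range from 0.03 h to 0.12 h.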

Compound 3, half-life: 0.05 h
For compound 3 the middle estimate is 1.2-fold (0.08 log units) above the measured one, within the range that was stated.
By their numbers in this assay, from the lowest: compounds 1, 3 and 2 (each within the scatter of the next).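

In this assay the earlier pair had a ring on both sides of the change, whereas compound 3 has none in this group, and the step of a 1.3-fold lower number from compound 2 to compound 3 (0.13 log units; within the scatter) shows that replacing cyclohexyl with open-chain isopentyl on this carbonyl carbon stays level. The step of no change at the digits printed from compound 1 to compound 3 (within the scatter) extends this reading, since isopropyl in place of cyclopentyl along the chain also leaves the number level. No measured evidence accounts for these level readings.

From the compounds shown here alone, all three compounds carry only a saturated hydrocarbon group on this carbonyl carbon, so it remains open whether an amine, a carboxylic acid or an ether oxygen there would move the half-life beyond the scatter. Going by these compounds, it also remains open whether any change to the shared core would do so.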